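This account rests on a few compounds, and the source may have more. Where it says the series, first, only, none or still open, it means among the compounds named here.

In a functional assay on HL-60 cells (Homo sapiens) for antiproliferative activity, read by MTT assay, with a stated time of 48 h (on this read-out higher numbers stand for weaker inhibition and lower numbers for stronger inhibition), compound 1 `CN(C)CCn1c(N)c(-c2nc3ccccc3[nH]2)c2nc(C#N)c(C#N)nc21` gives 2220 nM and compound 2 `CN(C)CCCn1c(N)c(-c2nc3ccccc3[nH]2)c2nc(C#N)c(C#N)nc21` gives 870 nM. Compound 3 `CN(C)CCn1c(N)c(-c2nc3ccccc3n2C)c2nc(C#N)c(C#N)nc21` reads > 50000 nM, which is a limit of the assay and not a number. Compound 4 `CN(C)CCCn1c(N)c(-c2nc3ccccc3n2C)c2nc(C#N)c(C#N)nc21` keeps the methyl on the aromatic nitrogen of compound 3 and differs from it in the side chain: (dimethylamino)methyl in place of dimethylamino on a saturated chain carbon, two bonds along the chain from an aromatic nitrogen. Among the measured compounds shown here, two measured steps bear on this change. Methyl in place of hydrogen on the aromatic nitrogen gave an at least 22-fold higher number from compound 1 to compound 3 (1.35 log units; beyond the scatter), a large step that sets the low-activity starting point. The same chain change, made without that methyl, gave a 2.6-fold lower number from compound 1 to compound 2 (0.41 log units; beyond the scatter), a modest step. Taking that chain step as the guide, a modest move to lower numbers is expected in this assay, although the starting point is known only as a limit and compound 4 may also return only a limit. The expected step is an at least 1.6-fold lower number from compound 3 to compound 4 (0.22 log units; that floor lies within the scatter). For compound 4 the estimated value is 30000 nM, with an expected range of 9000 nM to 70000 nM.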

Compound 4, half-maximal inhibitory concentration: 2120 nM
Beside the measured number, compound 4's estimate is 14-fold (1.15 log units) above it; the measured number lies below the stated range.
By their numbers in this assay, from the lowest: compound 2; then compounds 4 and 1 (each within the scatter of the next). At a limit, above all of these: compound 3.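

In this assay, the change from 2-(dimethylamino)ethyl to 3-(dimethylamino)propyl gives an at least 23-fold lower number from compound 3 to compound 4 (1.37 log units; beyond the scatter), so it counts for far more when the aromatic nitrogen carries a methyl: the same change on two cores in this assay, a 2.6-fold lower number (0.41 log units; beyond the scatter) from compound 1 to compound 2 and an at least 23-fold lower number (1.37 log units; beyond the scatter) from compound 3 to compound 4, at least 9.2-fold (0.96 log units) apart, beyond the scatter of two such steps
Compound 3 stands at > 50000 nM, which is a limit of the assay and not a number.
With the 3-(dimethylamino)propyl chain in place, methyl on the aromatic nitrogen gives only a 2.4-fold higher number from compound 2 to compound 4 (0.39 log units; beyond the scatter), so the large loss seen with the 2-(dimethylamino)ethyl chain does not carry over: the same change on two cores in this assay, an at least 22-fold higher number (1.35 log units; beyond the scatter) from compound 1 to compound 3 and a 2.4-fold higher number (0.39 log units; beyond the scatter) from compound 2 to compound 4, at least 9.2-fold (0.96 log units) apart, beyond the scatter of two such steps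

The compounds shown leave open how a longer chain, or a morpholine in place of the dimethylamino group, would read with the methyl on the aromatic nitrogen. They also leave open whether ethyl on that nitrogen would be met by the 3-(dimethylamino)propyl chain in the same way, and why the two changes depend on each other.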